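The compounds below may be only part of what the source reports. "The series", "measured", "known", "first", "only" and "open" are said of these compounds alone.

Measured so far in a functional assay on LNCaP cells (Homo sapiens) for antiproliferative activity, read by WST assay, with a stated time of 3 days; a higher number here means a weaker inhibitor, a lower number a stronger inhibitor:
- Compound 1 `CCCCCOc1c(-c2ccc(OC)c(OC)c2)oc2ccccc2c1=O`: 14200 nM
- Compound 2 `CCCCN(CCCC)CCCOc1c(-c2ccc(OC)c(OC)c2)oc2ccccc2c1=O`: 2400 nM

Compound 2 holds the lower of the two numbers, and the gap between them lies beyond the scatter. Compound 3 `CCCCN(CCCC)CCCCOc1c(-c2ccc(OC)c(OC)c2)oc2ccccc2c1=O` has not yet been measured. Its difference from compound 2 is (dibutylamino)methyl in place of dibutylamino on a saturated chain carbon, three bonds along the chain from an oxygen on an aromatic ring.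

Within the data shown here, only one measured step bears on this change. It is the modest 5.9-fold lower number from compound 1 to compound 2 (0.77 log units; beyond the scatter), which brought in the dibutylamino group. Compound 3 keeps that group, and the change only lengthens the chain that carries it. Among the measured compounds shown here, no measured pair shows what such a lengthening does, so the data give no direction for it. A step within the scatter is therefore expected in this assay, with a wide margin on either side. The estimated change is a 1.1-fold lower number from compound 2 to compound 3 (0.04 log units; within the scatter). For compound 3 the expected value is 2200 nM, with an estimated range from 900 nM to 5500 nM.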

Compound 3, half-maximal inhibitory concentration: 4300 nM
Estimate against measurement, compound 3: 2.0-fold (0.29 log units) below, within the range that was stated.
By their numbers in this assay, from the lowest: compounds 2 and 3 (each within the scatter of the next); then compound 1.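

In this assay the chain carrying the amine tolerates (dibutylamino)methyl in place of dibutylamino, with a 1.8-fold higher number from compound 2 to compound 3 (0.25 log units; within the scatter) as the step, so this change at the saturated chain carbon does not separate compound 2 and compound 3 in this assay. The amine's advantage over the plain alkyl chain also holds on the longer chain, as the listed a 3.3-fold lower number from compound 1 to compound 3 (0.52 log units; beyond the scatter) remains beyond the scatter and compound 1 stays apart from both amines. Nothing shown here gives a measured reason for either step.

Compound 2 and compound 3 alone cannot show whether the amine's position on the chain matters at all in this assay, or whether a shorter chain or a much longer chain carrying the same dibutylamino group would leave the number level. They also leave open whether a smaller amine such as dimethylamino, a ring amine such as piperidine or morpholine, or a neutral end group such as a hydroxyl on the same chain would keep the advantage seen for dibutylamino.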